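The compounds below may be only part of what the source reports. "The series", "measured", "known", "first", "only" and "open" are said of these compounds alone.

Working notes on the series. Compound 3 `CN(C)CC1CCC/C(=C\c2ccc(OC(=O)c3ccccc3)cc2)C1=O` gives the highest number of the three measured in a functional assay on MOLT-4 cells (Homo sapiens) (on this read-out higher numbers stand for weaker inhibition and lower numbers for stronger inhibition), at 24100 nM. Compound 1 `Cc1ccc(/C=C/C(=O)Oc2ccc(/C=C3\CCCC(CN(C)C)C3=O)cc2)cc1` gives 3390 nM in this assay, and compound 2 `CN(C)CC1CCC/C(=C\c2ccc(OC(=O)/C=C/c3ccc(F)cc3)cc2)C1=O` gives 3780 nM. The two steps leading to compound 3 are of similar size: a 7.1-fold higher number from compound 1 to compound 3 (0.85 log units; beyond the scatter) and a 6.4-fold higher number from compound 2 to compound 3 (0.80 log units; beyond the scatter), both beyond the scatter. Within the data shown here, the only substituent swap measured on the acyl aryl ring is a 1.1-fold higher number from compound 1 to compound 2 (0.05 log units; within the scatter), which stays within the scatter.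

Compound 4 `CN(C)CC1CCC/C(=C\c2ccc(OC(=O)c3ccc(Cl)cc3)cc2)C1=O` is the next member, with the change (chloro in place of hydrogen on an aromatic carbon). Among the measured compounds shown here, no step on the benzoyl ring of compound 3 itself has been measured; the nearest guide is the aryl swap between compound 1 and compound 2, which moved the number by a 1.1-fold higher number from compound 1 to compound 2 (0.05 log units; within the scatter). A step in this assay of no more than the scatter is therefore expected, in either direction. The estimate for compound 4 is 20000 nM, with a range of 7000 nM to 55000 nM, meaning an expected step of a 1.2-fold lower number from compound 3 to compound 4 (0.08 log units; within the scatter).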

Compound 4, half-maximal inhibitory concentration: 5110 nM
Estimate against measurement, compound 4: 3.9-fold (0.59 log units) above; measured number below the stated range.
By their numbers in this assay, from the lowest: compounds 1, 2 and 4 (each within the scatter of the next); then compound 3.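

In this assay the benzoyl ring of compound 3 responds at the place para to a large group: chloro in place of hydrogen gives a 4.7-fold lower number from compound 3 to compound 4 (0.67 log units; beyond the scatter) and so goes beyond the scatter, whereas the fluoro for methyl swap on the other aryl ring gave a 1.1-fold higher number from compound 1 to compound 2 (0.05 log units; within the scatter) and stayed within it. The 4-chlorophenyl group also brings the short acyl compound level with the two ethenyl compounds, with a 1.4-fold higher number from compound 2 to compound 4 (0.13 log units; within the scatter) and a 1.5-fold higher number from compound 1 to compound 4 (0.18 log units; within the scatter) both within the scatter, so the ethenyl chain is not needed for numbers of this size once chloro is present. Nothing measured on these compounds accounts for the step.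

The compounds shown leave open whether a methoxy or a nitro group at this place would move the number as chloro does. Also open, from the compounds shown here alone, is whether chloro on the aryl ring of the ethenyl compounds would lower their numbers further.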